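This account rests on a few compounds, and the source may have more. Where it says the series, first, only, none or still open, it means among the compounds named here.

In a physicochemical assay for solubility, measured as kinetic solubility, at pH 2 (a higher number here means a more soluble compound, a lower number a less soluble compound), compound 1 `CC(C)C(c1ccc(-c2ccc3cccc(F)c3c2)[nH]c1=O)C1NC(=O)NC1=O` gives 5800 nM, the lower of the two numbers available. Compound 2 `O=C1NC(=O)/C(=C/C2(c3ccc(-c4ccc5cccc(F)c5c4)[nH]c3=O)CC2)O1` gives 27400 nM, a gap beyond the usual scatter. Compound 3 `CC(C)C(/C=C1/C(=O)NC(=O)N1C)c1ccc(-c2ccc3cccc(F)c3c2)[nH]c1=O` has not yet been measured. It keeps the core of compound 1 and changes one group, on a saturated chain carbon bound to an aromatic carbon and a saturated chain carbon: a group of 9 heavy atoms (5 carbon, 2 nitrogen, 2 oxygen; one five-membered non-aromatic ring with 2 hetero atoms) in place of a group of 7 heavy atoms (3 carbon, 2 nitrogen, 2 oxygen; one five-membered non-aromatic ring with 2 hetero atoms), on a saturated chain carbon bound to an aromatic carbon and a saturated chain carbon. Among the measured compounds shown here, no measured pair shows this change alone, so the size of the step can only be judged loosely. The value of compound 2, 27400 nM, shows that this series can reach higher numbers, but compound 2 differs from compound 1 in more than one place. A small step is expected, with no shift beyond the scatter. The estimated step is a 1.2-fold lower number from compound 1 to compound 3 (0.06 log units; within the scatter). Compound 3 is expected to give about 5000 nM, within an estimated range of 1500 nM to 18000 nM.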

Compound 3, solubility: 8300 nM
Compound 3: middle estimate off by 1.7-fold (0.22 log units), on the low side, and the stated range covers the measured number.
By their numbers in this assay, from the lowest: compounds 1 and 3 (each within the scatter of the next); then compound 2.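

In this assay, the change on a saturated chain carbon bound to an aromatic carbon and a saturated chain carbon gives a 1.4-fold higher number from compound 1 to compound 3 (0.16 log units; within the scatter) and so does not separate the two compounds. At this position, then, the 2,5-dioxoimidazolidin-4-yl group can give way to a ring group with more heavy atoms and one hydrogen-bond donor in place of two, without a shift beyond the scatter. No measurement shown here accounts for this result. Going by these compounds, whether a group of another kind at this position, such as an amine or a carboxylic acid, would give a similar number remains open. Compound 2 differs from compound 1 in more than one place, and the compounds shown do not tell which of those places sets its number.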